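The compounds below may be only part of what the source reports. "The series", "measured", "known", "first", "only" and "open" are said of these compounds alone.

Compound 1, `CCCc1cc(C)c(C(=O)N=C(N)N)cc1S(C)(=O)=O`: 5.7 nM
Compound 2, `Cc1cc(Oc2cccc(Cl)c2)c(S(C)(=O)=O)cc1C(=O)N=C(N)N`: 21 nM

Within the data shown here, in a functional assay for inhibition of sodium/hydrogen exchanger (Oryctolagus cuniculus) (a higher number here means a weaker inhibitor, a lower number a stronger inhibitor), compound 2 gives the higher of the two numbers so far. Among the measured compounds shown here, the only measured step is a 3.7-fold higher number from compound 1 to compound 2 (0.57 log units; beyond the scatter), a change that put 3-chlorophenoxy in place of propyl on an aromatic carbon.

Compound 3, `Cc1cc(N2CCCC2)c(S(C)(=O)=O)cc1C(=O)N=C(N)N`, differs from compound 2 by pyrrolidin-1-yl in place of 3-chlorophenoxy on an aromatic carbon. For the measured compounds named here, no measured step involves a pyrrolidin-1-yl group, so the single known step is only loosely related; its size was modest. A step near the scatter, in either direction, is therefore expected, written as a 1.4-fold lower number from compound 2 to compound 3 (0.15 log units; within the scatter). Compound 3 is estimated at 15 nM, within 4 nM to 60 nM.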

Compound 3, half-maximal inhibitory concentration: 11 nM
Compound 3: the middle estimate sits 1.4-fold (0.13 log units) above what was measured; the range from low to high includes it.
By their numbers in this assay, from the lowest: compounds 1, 3 and 2 (each within the scatter of the next, the first and the last beyond it).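

In this assay, the carbon ortho to the methylsulfonyl group also carries a five-membered non-aromatic ring, pyrrolidin-1-yl, and neither step separates it from the earlier groups: there is a 1.9-fold lower number from compound 2 to compound 3 (0.28 log units; within the scatter), and a 1.9-fold higher number from compound 1 to compound 3 (0.29 log units; within the scatter). Pyrrolidin-1-yl thus cannot be ranked against propyl or 3-chlorophenoxy, although those two differ from each other beyond the scatter. No measurement here gives a reason for this result. On these data alone, it remains open whether an open-chain amine such as dimethylamino, or a larger ring such as piperidin-1-yl or morpholin-4-yl, would give a similar number at this position.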